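Swapping Nitro for Chloro on a Scaffold Without Activity

The source may report more compounds than this note shows. Statements on the series, on what has been measured and on what is new or still open speak of the compounds shown alone.

Of the compounds shown here, two have been tested in a functional assay on MCF7 cells (Homo sapiens) for antiproliferative activity, read by MTT assay; on this read-out higher numbers stand for weaker inhibition and lower numbers for stronger inhibition. Compound 1 `CN1C(=O)/C(=C2\S/C(=N/c3ccc(S(N)(=O)=O)cc3)NC2=O)c2cc(Cl)ccc21` reaches only a limit of the assay, > 200000 nM, and no number. Compound 2 `NS(=O)(=O)c1ccc(/N=C2\NC(=O)/C(=C3/C(=O)Nc4ccc([N+](=O)[O-])cc43)S2)cc1` likewise stops at a limit, > 200000 nM. Compound 2 therefore stands at the limit of > 200000 nM in this assay, at which 2 of the 2 values shown sit, with no measured number below it. Compound 3 `NS(=O)(=O)c1ccc(/N=C2\NC(=O)/C(=C3/C(=O)Nc4ccc(Cl)cc43)S2)cc1` arises from compound 2 by chloro in place of nitro on an aromatic carbon. With every measured value sitting at a limit, no step beyond the scatter is expected, and the change is estimated at a number no higher from compound 2 to compound 3 (the limit leaves the size open). Compound 3 is expected to give about 200000 nM in this assay, within 50000 nM to 400000 nM.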

Compound 3, half-maximal inhibitory concentration: 3960 nM
The estimate for compound 3 lay 51-fold (1.70 log units) above the measured number; the measured number lies below the stated range.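

Chloro in place of nitro on this aromatic carbon brings an at least 50-fold lower number from compound 2 to compound 3 (1.70 log units; beyond the scatter), so this one position can decide whether the shared core gives a measured number at all. Hydrogen in place of methyl on the amide-type nitrogen in a ring brings an at least 50-fold lower number from compound 1 to compound 3 (1.70 log units; beyond the scatter), so, with chloro present, that nitrogen matters as well. Only compound 3 gives a measured number, while the other two compounds stop at a limit: the limit of > 200000 nM in this assay, at which 2 of the 3 values shown sit.

Going by these compounds, because both steps start from a limit, their true size stays open. On these data alone, it is also open how an amine or a methoxy group would compare with chloro at this position.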